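Inverting the chain stereocentre of compound 3

The compounds below may be only part of what the source reports. "The series", "measured", "known", "first", "only" and "open" are said of these compounds alone.

Measured so far in an ADME assay (Mus musculus, strain C57BL/6) for metabolic stability, read by HPLC, with a stated time of 12 h; a higher number here means that the compound lasts longer, a lower number that the compound disappears faster:
- compound 1 `O=C(O)[C@H](CO)NC(=O)[C@H]1C[C@@H](O)CN1`: > 12 h
- compound 2 `O=C(O)[C@H](CO)NC(=O)[C@@H]1C[C@H](O)CN1`: 1.22 h
- compound 3 `O=C(N[C@H](CO)C(=O)O)[C@@H]1C[C@@H](O)CN1`: 0.91 h

The value of compound 1 is a limit of this assay, not a number (the limit of > 12 h in this assay, at which 1 of the 3 values shown sits). Among the two numbers, compound 3 and compound 2 lie within the scatter of each other, as the step of a 1.3-fold lower number from compound 2 to compound 3 (0.13 log units; within the scatter) shows. Both sit well apart from compound 1: an at least 9.8-fold lower number from compound 1 to compound 2 (0.99 log units; beyond the scatter) and an at least 13-fold lower number from compound 1 to compound 3 (1.12 log units; beyond the scatter), and the three compounds differ only in configuration (the fact that compounds 1 and 2 differ only in the configuration as drawn, (the fact that compounds 1 and 3 differ only in the configuration as drawn), (the fact that compounds 2 and 3 differ only in the configuration as drawn)).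

Compound 4 `O=C(O)[C@H](CO)NC(=O)[C@@H]1C[C@@H](O)CN1` is the next step. Relative to compound 3, (the two compounds have the same atoms and bonds and differ only in configuration as drawn: 1 of 3 stereo elements differ; a stereocentre at a saturated chain carbon is drawn R in compound 3 and S in compound 4).

Among the measured compounds shown here, no measured step changes this chain stereocentre alone. It is changed in an at least 13-fold lower number from compound 1 to compound 3 (1.12 log units; beyond the scatter) together with a ring stereocentre, and in a 1.3-fold lower number from compound 2 to compound 3 (0.13 log units; within the scatter) together with another ring stereocentre, with very different outcomes. The change at the chain carbon therefore cannot be separated from the ring changes, and no clear direction follows. The expected step is a 1.6-fold higher number from compound 3 to compound 4 (0.22 log units; within the scatter), a modest shift that stays close to the scatter.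

Compound 4 is estimated at 1.5 h, within 0.5 h to 6 h.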

Compound 4, half-life: 0.86 h
For compound 4 the middle estimate is 1.7-fold (0.24 log units) above the measured one; measured number inside the range.
By their numbers in this assay, from the lowest: compounds 4, 3 and 2 (each within the scatter of the next). At a limit, above all of these: compound 1.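

In this assay, among the compounds shown here, the chain stereocentre can now be read on its own for the first time, and with the ring stereocentres as in compound 3, the step of a 1.1-fold lower number from compound 3 to compound 4 (0.02 log units; within the scatter) shows that the two compounds cannot be told apart at this carbon. For the compounds shown here, compound 4 also separates the two ring stereocentres, which earlier steps changed only in pairs: one gives an at least 13-fold lower number from compound 1 to compound 4 (1.14 log units; beyond the scatter), the only single change here that goes beyond the scatter, while the other gives a 1.4-fold lower number from compound 2 to compound 4 (0.15 log units; within the scatter), which stays within it. As far as these compounds go, the value of compound 1, > 12 h, is a limit of this assay and not a number, so the true size of that step remains unknown.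

The compounds shown leave open whether the chain stereocentre would count for as little with the ring stereocentres as in compound 1, the one compound at the limit. They also leave open how a methyl ester in place of the carboxylic acid, or a methoxy group in place of the hydroxyl on the ring, would behave in this assay.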